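Replacing 3-chloro-2-methoxyphenyl with 2-methylpyridin-3-yl

The source may report more compounds than this note shows. Statements on the series, on what has been measured and on what is new or still open speak of the compounds shown alone.

Compound 1 (`CCOc1ccccc1-c1ccc(-c2nc3cnccc3c(NC(C)C(=O)O)c2C#N)cc1`) reads 2.1 in a physicochemical assay for lipophilicity, read by HPLC, at pH 7.5 (a higher number here means a more lipophilic compound, a lower number a more polar compound), and compound 2 (`CCOc1ccccc1-c1ccc(-c2nc3cncc(Cl)c3c(N[C@H](CC)C(N)=O)c2C#N)cc1`) reads 3.7 there, while compound 3 (`CC[C@@H](Nc1c(C#N)c(-c2ccc(-c3cccc(Cl)c3OC)cc2)nc2cnccc12)C(N)=O`) reads 3.1 on the same scale. That places compound 3 second of the three, with compound 2 higher and compound 1 lower, both gaps beyond the scatter. Compound 4 (`CC[C@@H](Nc1c(C#N)c(-c2ccc(-c3cccnc3C)cc2)nc2cnccc12)C(N)=O`) has 2-methylpyridin-3-yl in place of the 3-chloro-2-methoxyphenyl of compound 3, on an aromatic carbon, para to a large group (2-methylpyridin-3-yl in place of 3-chloro-2-methoxyphenyl on an aromatic carbon). Among the measured compounds shown here, no measured pair shows this change, so the expectation rests on the structures alone. A fall beyond the scatter is expected in this assay (an estimated a number 0.90 log units lower from compound 3 to compound 4 (beyond the scatter)). For compound 4 the estimated value is 2.2 (expected range 1.7 to 2.7).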

Compound 4, distribution coefficient: 1.9
Compound 4: middle estimate off by 0.30 log units, on the high side, and the stated range covers the measured number.
By their numbers in this assay, from the lowest: compounds 4 and 1 (each within the scatter of the next); then compound 3; then compound 2.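

In this assay, putting 2-methylpyridin-3-yl in place of 3-chloro-2-methoxyphenyl gives a number 1.20 log units lower from compound 3 to compound 4 (beyond the scatter), the first step seen at this place on the aromatic carbon, para to a large group. This single exchange therefore moves the read-out by a large amount with the rest of the structure unchanged. Nothing at hand bears on what lies behind the step.

The compounds shown leave open which part of the exchange carries the step, as the chlorine, methoxy, ring nitrogen and methyl all change together. Also open, going by these compounds, is where a plain phenyl or a 2-methoxypyridin-3-yl group would read at this place.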